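The source may hold more compounds than are shown below. What is called first, only, known or untested is meant among the compounds shown, and "the series" means these compounds.

In a functional assay on A549 cells (Homo sapiens) for antiproliferative activity, read by MTT assay, with a stated time of 48 h (a lower number here means a stronger inhibitor, a higher number a weaker inhibitor), compound 1 (`CCNc1nccc2ncc(-c3cnn(C)c3)cc12`) gives 40700 nM and compound 2 (`Cn1cc(-c2cnc3ccnc(NCC4CC4)c3c2)cn1`) gives 8900 nM, the lower of the two numbers. Compound 3 (`Cn1cc(-c2cnc3ccnc(NS(=O)(=O)c4cccs4)c3c2)cn1`) keeps the shared core of compound 2 but carries (thiophen-2-yl)sulfonyl in place of cyclopropylmethyl on a nitrogen on an aromatic ring, ((thiophen-2-yl)sulfonyl in place of cyclopropylmethyl on a nitrogen on an aromatic ring). For the measured compounds named here, only one measured step bears on this change: a 4.6-fold lower number from compound 1 to compound 2 (0.66 log units; beyond the scatter), modest but beyond the scatter. Going by the values given here, it alters the group on that same nitrogen, yet it exchanges only cyclopropyl for methyl, and no measured compound carries a sulfonyl group, so it offers a guide to scale rather than direction. A modest move to a higher number is expected, with wide uncertainty, a 2.0-fold higher number from compound 2 to compound 3 (0.31 log units; beyond the scatter). The estimated value for compound 3 is 18000 nM, with an expected range of 5000 nM to 60000 nM.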

Compound 3, half-maximal inhibitory concentration: 9400 nM
Compound 3: the middle estimate sits 1.9-fold (0.28 log units) above what was measured, within the range that was stated.
By their numbers in this assay, from the lowest: compounds 2 and 3 (each within the scatter of the next); then compound 1.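

In this assay, a 1.1-fold higher number from compound 2 to compound 3 (0.02 log units; within the scatter) follows the exchange of cyclopropylmethyl for (thiophen-2-yl)sulfonyl, so two very different groups on this nitrogen give readings that the scatter does not separate. Until now only simple alkyl groups had been seen at this place, and the sulfonyl group shows that the place also tolerates a larger group with an aromatic ring, while a 4.3-fold lower number from compound 1 to compound 3 (0.64 log units; beyond the scatter) sets it apart from ethyl by about as much as cyclopropylmethyl was. Nothing given here accounts for this match between the two groups. From the compounds shown here alone, whether a benzenesulfonyl group, an acetyl group or the free amine on this nitrogen would fit the same picture remains open. So does the part played by the thiophene ring, as against the sulfonyl group alone.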